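Dropping All Substituents From the Benzyl Group

A few compounds are considered here, and "the series" means these few. Any claim that something is new, unique, unknown or untested is made for them only; others in the source may bear on it.

Measured so far:
- compound 1, `COc1cc(F)c(CN2C(=O)N(c3ccc(OC)c(OC)c3)S(=O)(=O)c3ccccc32)c(F)c1`: 0.501 nM
- compound 2, `COc1ccc(N2C(=O)N(Cc3c(F)cccc3Cl)c3ccccc3S2(=O)=O)cc1OC`: 0.794 nM
- compound 3, `COc1ccc(N2C(=O)N(Cc3c(F)cc(C)cc3Cl)c3ccccc3S2(=O)=O)cc1OC`: 0.794 nM

In an assay on HEK293 cells for displacement of a labelled ligand from Orexin receptor type 2 (Homo sapiens), read by scintillation counting, with a stated time of 90 min (a lower number here means a stronger inhibitor, a higher number a weaker inhibitor), compound 3 gives 0.794 nM, level with compound 2 at the digits shown and, together with it, the highest of the three numbers; the gap to compound 1 is within the scatter. Compound 4, `COc1ccc(N2C(=O)N(Cc3ccccc3)c3ccccc3S2(=O)=O)cc1OC`, carries the change (phenyl in place of 2-chloro-6-fluoro-4-methylphenyl on a saturated chain carbon bound to an amide-type nitrogen in a ring). The earlier steps shown here, a 1.6-fold higher number from compound 1 to compound 2 (0.20 log units; within the scatter), a 1.6-fold higher number from compound 1 to compound 3 (0.20 log units; within the scatter) and no change at the digits printed from compound 2 to compound 3 (within the scatter), all swapped one substituted phenyl for another and stayed within the scatter; none removed every substituent at once, so they do not directly cover this change. A modest rise in this assay is expected, a 3.8-fold higher number from compound 3 to compound 4 (0.58 log units; beyond the scatter), giving compound 4 an estimated 3 nM within 0.7 nM to 15 nM.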

Compound 4, inhibition constant: 79.4 nM
For compound 4 the middle estimate is 26-fold (1.42 log units) below the measured one; the measured number lies above the stated range.
By their numbers in this assay, from the lowest: compounds 1, 2 and 3 (each within the scatter of the next); then compound 4.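

In this assay, the steps among compounds 1, 2 and 3 stayed within the scatter, but removing every substituent from the benzyl ring gives a 100-fold higher number from compound 3 to compound 4 (2.00 log units; beyond the scatter), a 100-fold higher number from compound 2 to compound 4 (2.00 log units; beyond the scatter) and a 160-fold higher number from compound 1 to compound 4 (2.20 log units; beyond the scatter). Compound 2 lacks the methyl and prints the same value as compound 3, so this loss goes with removing the chloro and fluoro substituents together. Nothing available explains the loss.

Going by these compounds, whether one halogen alone would restore the low numbers remains open. So does the effect of a different substituent on this ring, such as a nitrile.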